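A few compounds are considered here, and "the series" means these few. Any claim that something is new, unique, unknown or untested is made for them only; others in the source may bear on it.

Measured so far:
Compound 1 `Cc1c(O)nc(SCc2ccc(C#N)cc2)nc1Cc1c(F)cccc1F`: > 65000 nM (a limit)
Compound 2 `COc1ccc(CSc2nc(O)c(C)c(Cc3c(F)cccc3F)n2)cc1`: > 64000 nM (a limit)

In a functional assay on MT4 cells (Homo sapiens) for cytotoxicity, read by MTT assay (a lower number here means that less compound is tolerated, a higher number that more compound is tolerated), compound 2 gives no exact number, only the limit > 64000 nM. Compound 1 also gives only a limit, > 65000 nM. Neither compound therefore fixes the concentration that harms the cells.

Compound 3 `Cc1c(O)nc(SCc2ccc(C(C)C)cc2)nc1Cc1c(F)cccc1F` keeps the shared core and changes one group, with isopropyl in place of methoxy on an aromatic carbon.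

For the measured compounds named here, the only measured step that bears on this change is at the same place on the ring: a step that the two limits leave unreadable from compound 1 to compound 2. It offers no size to carry over, so no step beyond the scatter is expected in this assay, and no direction can be argued. The expected step is an at least 1.0-fold lower number from compound 2 to compound 3 (0.02 log units; that floor lies within the scatter). For compound 3 the estimated value is 60000 nM, with an expected range from 20000 nM to 90000 nM.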

Compound 3, half-maximal cytotoxic concentration: > 62000 nM
Compound 3: a limit, no number; the forecaster's own chance of this, stated with the estimate: 70%; at least 1.0-fold (0.01 log units) between middle value and limit.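

For the compounds shown here, compound 1, compound 2 and compound 3 each give only a limit in this assay, so no step between them can be read. The compounds shown leave open the concentration at which any of them harms the cells, and whether swapping the ring group shifts it.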